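A few compounds are considered here, and "the series" means these few. Any claim that something is new, unique, unknown or untested is made for them only; others in the source may bear on it.

Two pairs of compounds here share one structural change. Compound 1 `O=C(N/N=C/c1ccc([N+](=O)[O-])o1)c1ccc(Cl)cc1` carries a chloro group on its outer benzene ring, and compound 2 `O=C(N/N=C/c1ccc([N+](=O)[O-])o1)c1ccc([N+](=O)[O-])cc1` differs from it only by nitro in place of chloro on an aromatic carbon. In an ADME assay on J774 cells (Mus musculus) for cytotoxicity, read by MTT assay, with a stated time of 48 h (on this read-out higher numbers stand for weaker inhibition and lower numbers for stronger inhibition), compound 1 gives 57100 nM. In the same this assay compound 2 gives 79100 nM. The step of a 1.4-fold higher number from compound 1 to compound 2 (0.14 log units; within the scatter) shows that this swap hardly moved the read-out for this pair.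

Compound 3 `CC(=O)N1N=C(c2ccc(Cl)cc2)OC1c1ccc([N+](=O)[O-])o1` is built on a different core; how its core differs from that of compound 1 is not broken down here. In this assay compound 3 gives > 400000 nM, and that value is a limit of the assay rather than a number, as the limit of > 400000 nM in this assay, at which 1 of the 3 values shown sits, records. Among the compounds with values here, compound 4 `CC(=O)N1N=C(c2ccc([N+](=O)[O-])cc2)OC1c1ccc([N+](=O)[O-])o1` has not yet been measured; it differs from compound 3 by nitro in place of chloro on an aromatic carbon, which is the same change, at the same place, as the one from compound 1 to compound 2.

What can be expected for compound 4 rests on the measured pair: because a 1.4-fold higher number from compound 1 to compound 2 (0.14 log units; within the scatter) stayed within the usual scatter, the same swap is expected to leave the read-out of compound 3 largely where it is, most likely again at the limit of the assay. Compound 4 is therefore expected to give around 500000 nM in this assay, with a plausible range from 250000 nM to 1200000 nM. This estimate means an expected step that the limit leaves unreadable from compound 3 to compound 4.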

Compound 4, half-maximal inhibitory concentration: 114000 nM
Compound 4: the middle estimate sits 4.4-fold (0.64 log units) above what was measured; the whole stated range lies above it.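

In this assay, the swap of nitro in place of chloro on an aromatic carbon gives an at least 3.5-fold lower number from compound 3 to compound 4 (0.54 log units; beyond the scatter), and a lower number here stands for stronger inhibition, meaning that compound 4 harms the cells at lower concentrations than compound 3 does. The change that hardly moved the read-out on the core of compound 1 therefore does move it on the core of compound 3, so in this series the size of its effect cannot simply be carried from one core to the other: the same change on two cores in this assay, a 1.4-fold higher number (0.14 log units; within the scatter) from compound 1 to compound 2 and an at least 3.5-fold lower number (0.54 log units; beyond the scatter) from compound 3 to compound 4, at least 4.8-fold (0.68 log units) apart, beyond the scatter of two such steps What this does not show is why the two cores respond differently or how large the step truly is, for compound 3 is pinned down only by a limit of the assay, not by a number: the limit of > 400000 nM in this assay, at which 1 of the 4 values shown sits.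

The compounds shown place only chloro and nitro on the six-membered aromatic ring, and on just two cores, so it remains open whether other groups would also behave differently on the two cores. An amine or a carboxylic acid at that same place on each core would show whether the gap seen here is particular to this swap or extends to other groups.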